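The compounds below may be only part of what the source reports. "The series", "measured", "known", "first", "only" and "open" are said of these compounds alone.

Compound 2 `CC(=O)Nc1ncc(CN2CCN(CC(=O)Nc3ccc(Cl)cc3)CC2C)s1` stands lowest of the two compounds measured in an assay on isolated protein for inhibition of hexosaminidase D (Homo sapiens), tested at 10 uM (a lower number here means less inhibition, a higher number more inhibition at the concentration tested (going by the name of the read-out)), where compound 2 gives 92.4%; compound 1 `CC(=O)Nc1ncc(CN2CCN(CC(=O)Nc3ccccc3)CC2C)s1` gives 103%, and the step of a number 10.6 percentage points lower from compound 1 to compound 2 (beyond the scatter) came with chloro in place of hydrogen on an aromatic carbon. Compound 3 `CC(=O)Nc1ncc(CN2CCN(CC(=O)Nc3ccc(N4CCN(C(C)=O)CC4)cc3)CC2C)s1` differs from compound 2 by 4-acetylpiperazin-1-yl in place of chloro on an aromatic carbon. Among the compounds with values here, only the step from compound 1 to compound 2 touches this aromatic carbon, and it was modest, so no step beyond the scatter is expected in this assay, that is a number 2.4 percentage points lower from compound 2 to compound 3 (within the scatter). Compound 3 is therefore expected to give 90%, between 65% and 105%.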

Compound 3, a percentage reported as inhibition, at one concentration (the size of the read-out at that concentration, not a potency): 73.5%
Compound 3: middle estimate off by 16.5 percentage points, on the high side; the range from low to high includes it.
By their numbers in this assay, from the lowest: compound 3; then compound 2; then compound 1.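

In this assay, this aromatic carbon turned out to be more sensitive to substitution than the chloro step alone had shown: 4-acetylpiperazin-1-yl in place of chloro gave a number 18.9 percentage points lower from compound 2 to compound 3 (beyond the scatter), and in place of hydrogen it gave a number 29.5 percentage points lower from compound 1 to compound 3 (beyond the scatter). The larger group thus lowered the number further than chloro did, though inhibition at the tested concentration did not disappear. Nothing available explains this drop. On these data alone, it remains open whether the piperazine ring or its acetyl carries the step, and how a free piperazine or a morpholine at this carbon would read.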